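The compounds below may be only part of what the source reports. "The series", "measured", "known", "first", "only" and "open" are said of these compounds alone.

Measured compounds:
compound 1 `COc1cccc(CN2C(=O)C(C3=NS(=O)(=O)c4cc(NS(C)(=O)=O)ccc4N3)=C(O)[C@@H]3[C@H]4CC[C@H](C4)[C@@H]32)c1` with 61% in an ADME assay on microsomes from liver (Homo sapiens) for metabolic stability, with a stated time of 60 min, tested at 1 uM; on this read-out lower numbers stand for a less stable compound and higher numbers for a more stable compound
compound 2 `CS(=O)(=O)Nc1ccc2c(c1)S(=O)(=O)N=C(C1=C(O)[C@@H]3[C@H]4CC[C@H](C4)[C@@H]3N(Cc3ccc(F)c(Cl)c3)C1=O)N2` with 87% in this assay

Compound 2 stands highest of the two numbers; its nearest neighbour is compound 1, and the step of a number 26 percentage points higher from compound 1 to compound 2 (beyond the scatter) lies beyond the scatter. Compound 3 `CS(=O)(=O)Nc1ccc2c(c1)S(=O)(=O)N=C(C1=C(O)[C@@H]3[C@@H]4CC[C@@H](C4)[C@@H]3N(Cc3ccc(F)c(Cl)c3)C1=O)N2` has not yet been measured in this assay. Its relation to compound 2 is the two compounds have the same atoms and bonds and differ only in configuration as drawn: 2 of 4 stereo elements differ; a stereocentre at a saturated ring carbon is drawn S in compound 2 and R in compound 3; a stereocentre at a saturated ring carbon is drawn R in compound 2 and S in compound 3. Going by the values given here, the one measured step, a number 26 percentage points higher from compound 1 to compound 2 (beyond the scatter), concerns an exchange of one aryl group for another and so does not bear on a change of configuration; no measured pair shows what inverting two stereocentres of the shared core does in this assay. Among the compounds with values here, with no step to lean on, the expectation is that compound 3 stays close to compound 2, and the step of a number 5 percentage points lower from compound 2 to compound 3 (within the scatter) is estimated to fall within the scatter, though the uncertainty is wide. Compound 3 is therefore expected to give 82% in this assay, with a range from 60% to 96%.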

Compound 3, percent of the compound remaining: 100%
The estimate for compound 3 lay 18 percentage points below the measured number; measured number above the stated range.
By their numbers in this assay, from the lowest: compound 1; then compound 2; then compound 3.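

In this assay, the change in drawn configuration at two saturated ring carbons of the shared core gives a number 13 percentage points higher from compound 2 to compound 3 (beyond the scatter), with the aryl group left as it is. Going by these compounds alone, the earlier step concerned only an exchange of one aryl group for another, so this result is the first sign that the configuration of the core also affects this read-out. The shift can be assigned to configuration alone, because nothing else separates the two structures: the fact that compounds 2 and 3 differ only in the configuration as drawn

Both stereocentres change together, so the compounds shown do not tell whether one of them alone accounts for the step, or whether the same inversion would raise the number of compound 1, which carries the 3-methoxyphenyl group. From the compounds shown here alone, it also remains open whether the configuration of compound 3 would keep its effect with an amine or a carboxylic acid on the aryl ring in place of the 3-chloro-4-fluorophenyl substituents.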